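The source may hold more compounds than are shown below. What is called first, only, known or untested is meant among the compounds shown, and "the series" means these compounds.

Measured compounds in an assay on isolated protein for inhibition of solute carrier family 22 member 12 (Homo sapiens), tested at 3 uM; on this read-out higher numbers stand for more inhibition at the one concentration tested (going by the name of the read-out) and lower numbers for less inhibition:
compound 1 `CCc1cc(C(=O)N2CC=CC2)cc(C#N)c1O` gives 54%;
compound 2 `CSc1cc(C(=O)N2CC=CC2)cc(C#N)c1O` gives 58%;
compound 3 `CCCc1cc(C(=O)N2CC=CC2)cc(C#N)c1O` gives 70%.

Compound 3 stands highest of the three, beyond the scatter of both compound 1 and compound 2. Compound 4 `CC(C)(C)c1cc(C(=O)N2CC=CC2)cc(C#N)c1O` differs from compound 3 in one place: tert-butyl in place of propyl on an aromatic carbon. Among the compounds with values here, two measured steps bear on this, both ending at compound 3: a number 16 percentage points higher from compound 1 to compound 3 (beyond the scatter) and a number 12 percentage points higher from compound 2 to compound 3 (beyond the scatter), each a modest rise. Between the two smaller groups the step of a number 4 percentage points higher from compound 1 to compound 2 (within the scatter) shows nothing beyond the scatter. Within the data shown here, no measured step branches the chain at this position; the direction is read from the two modest gains only. The expected step is a number 4 percentage points higher from compound 3 to compound 4 (within the scatter), small and possibly within the scatter. Compound 4 is estimated at 74%, between 58% and 88%.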

Compound 4, a percentage reported as inhibition, at one concentration (the size of the read-out at that concentration, not a potency): 92%
Beside the measured number, compound 4's estimate is 18 percentage points below it, and the stated range ends below it.
By their numbers in this assay, from the lowest: compounds 1 and 2 (each within the scatter of the next); then compound 3; then compound 4.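

In this assay, the position ortho to a hydroxy group responds to branching of the alkyl group: tert-butyl in place of propyl gives a number 22 percentage points higher from compound 3 to compound 4 (beyond the scatter). The same group gives a number 34 percentage points higher from compound 2 to compound 4 (beyond the scatter) and a number 38 percentage points higher from compound 1 to compound 4 (beyond the scatter), so this position spans a wider range than the three smaller groups showed. No measurement shown here explains the gain from tert-butyl.

As far as these compounds go, whether the gain follows the branching or the carbon count stays open. An isopropyl group and a butyl chain at this position would separate the two.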